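The source may report more compounds than this note shows. Statements on the series, on what has been measured and on what is new or still open speak of the compounds shown alone.

Measured so far in a functional assay on L1210 cells (Mus musculus) for inhibition; on this read-out higher numbers stand for weaker inhibition and lower numbers for stronger inhibition:

compound 1, `C#CCN(Cc1ccc2nc(C)nc(O)c2c1)c1cccc(C)c1`: compound 1 gives > 5000 nM, a limit of the assay and not a number.
compound 2, `C#CCN(Cc1ccc2nc(C)nc(O)c2c1)c1cccc(CC)c1`: compound 2 gives 5000 nM.
compound 3, `C#CCN(Cc1ccc2nc(C)nc(O)c2c1)c1cccc(C(F)(F)F)c1`: compound 3 gives > 2200 nM, again a limit of the assay.

Compound 1 thus stands at the limit of > 5000 nM in this assay, at which 1 of the 3 values shown sits, the weak end of what this assay reports. The step of a number no higher from compound 1 to compound 2 (the limit leaves the size open) cannot be sized, and neither can a step that the two limits leave unreadable from compound 1 to compound 3 or a step that the limit leaves unreadable from compound 2 to compound 3, since each involves a limit. Nothing in the three values separates the compounds beyond the scatter.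

Compound 4 is `C#CCN(Cc1ccc2nc(C)nc(O)c2c1)c1cccc(Br)c1`. It differs from compound 1 by bromo in place of methyl on an aromatic carbon. For the measured compounds named here, the one measured step at this aromatic carbon, a step that the two limits leave unreadable from compound 1 to compound 3, is unreadable, and no bromo analogue has been measured, so no step of a readable size bears on the change. The expectation is therefore a step that the limit leaves unreadable from compound 1 to compound 4, no step beyond the scatter, with a fair chance that the assay again reports only a limit. Compound 4 is estimated at 6000 nM, range 2500 nM to 15000 nM.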

Compound 4, half-maximal inhibitory concentration: 1800 nM
For compound 4 the middle estimate is 3.3-fold (0.52 log units) above the measured one; measured number below the stated range.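

In this assay the 3-methylphenyl to 3-bromophenyl change gives an at least 2.7-fold lower number from compound 1 to compound 4 (0.44 log units; beyond the scatter) and so shows that this aromatic carbon responds to the group placed on it, which the earlier values could not show. For the compounds shown here, the comparison with the ethyl analogue points the same way and gives the first step at this position with a measured size at both ends, namely a 2.8-fold lower number from compound 2 to compound 4 (0.44 log units; beyond the scatter) in this series. The comparison with trifluoromethyl remains undecided, with an at least 1.2-fold lower number from compound 3 to compound 4 (0.08 log units; that floor lies within the scatter) as no more than a floor on that step.

No measured property in these data bears on what separates bromo from methyl and ethyl. As far as these compounds go, whether chloro, a nitrile or a methoxy group at this carbon would match bromo remains open, as does the true size of the step between trifluoromethyl and bromo.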